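Ester alcohol change and metabolic stability in mouse microsomes

The source may hold more compounds than are shown below. What is called first, only, known or untested is meant among the compounds shown, and "the series" means these compounds.

Compound 1 `CCCCc1nc(C)c(CC(=O)OC2CCCCC2)c(=O)n1Cc1ccc(-c2ccccc2-c2noc(=O)[nH]2)cc1`: 10.7%
Compound 2 `CCCCc1nc(C)c(CC(=O)OCC2CCCCC2)c(=O)n1Cc1ccc(-c2ccccc2-c2noc(=O)[nH]2)cc1`: 8.9%

In an ADME assay on microsomes from liver (Mus musculus) for metabolic stability, with a stated time of 30 min (on this read-out lower numbers stand for a less stable compound and higher numbers for a more stable compound), compound 1 gives 10.7%, and compound 2 gives 8.9%. These two numbers lie within the scatter of each other: a number 1.8 percentage points lower from compound 1 to compound 2 (within the scatter). Compound 3 `CC#CCOC(=O)Cc1c(C)nc(CCCC)n(Cc2ccc(-c3ccccc3-c3noc(=O)[nH]3)cc2)c1=O` has not been measured; it differs from compound 2 in one place: prop-1-yn-1-yl in place of cyclohexyl on a saturated chain carbon bound to an oxygen next to a carbonyl group. Going by the values given here, the only measured step at this oxygen, a number 1.8 percentage points lower from compound 1 to compound 2 (within the scatter), was small, so no step beyond the scatter is expected: a number 1.1 percentage points higher from compound 2 to compound 3 (within the scatter). Compound 3 is therefore estimated at 10%, with a range of 3% to 25%.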

Compound 3, percent of the compound remaining: 18.3%
Compound 3: middle estimate off by 8.3 percentage points, on the low side; the range from low to high includes it.
By their numbers in this assay, from the lowest: compounds 2, 1 and 3 (each within the scatter of the next).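

Replacing the ring with a chain that has a triple bond gives, in this assay, a number 9.4 percentage points higher from compound 2 to compound 3 (within the scatter) and also a number 7.6 percentage points higher from compound 1 to compound 3 (within the scatter), so neither step goes beyond the usual variation between repeat measurements. This position has now carried groups with and without a ring, and no step among these three compounds exceeds the scatter. The available data offer no explanation for these numbers. As far as these compounds go, it remains open whether a chain carrying an amine or a carboxylic acid on this oxygen would give a step beyond the scatter.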